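Propargylamine thioethers: from a bromophenyl to a methoxyphenyl chain

This account rests on a few compounds, and the source may have more. Where it says the series, first, only, none or still open, it means among the compounds named here.

Measured so far:
compound 1, `C#CCNC1CCc2c(SCCc3ccc(Br)cc3)cccc21`, 1250 nM
compound 2, `C#CCNC1CCc2c(SCc3ccc(Br)cc3)cccc21`, 488 nM

Two compounds share the core and the propargylamine, and have been measured in an ADME assay on isolated protein for inhibition of Amine oxidase [flavin-containing] B (Homo sapiens); a lower number here means a stronger inhibitor, a higher number a weaker inhibitor. Compound 1 gives 1250 nM, the higher of the two numbers; compound 2 gives 488 nM, and the gap between these two values lies beyond the usual scatter. Compound 3, `C#CCNC1CCc2c(SCCc3cccc(OC)c3)cccc21`, has not been measured. It differs from compound 1 in one place: 3-methoxyphenyl in place of 4-bromophenyl on a saturated chain carbon, two bonds along the chain from a sulfur. Going by the values given here, no pair of measured compounds shows this change, so its size is unknown here. The account expects a modest step, towards a somewhat higher number, of about a 1.6-fold higher number from compound 1 to compound 3 (0.20 log units; within the scatter), since nothing in the two measured values speaks for a large gain. Compound 3 is therefore estimated at 2000 nM in this assay, within a range from 700 nM to 6000 nM.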

Compound 3, half-maximal inhibitory concentration: 3820 nM
Compound 3: the middle estimate sits 1.9-fold (0.28 log units) below what was measured, and the stated range covers the measured number.
By their numbers in this assay, from the lowest: compound 2; then compound 1; then compound 3.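

In this assay, the exchange of 4-bromophenyl for 3-methoxyphenyl on a saturated chain carbon, two bonds along the chain from a sulfur, gives a 3.1-fold higher number from compound 1 to compound 3 (0.49 log units; beyond the scatter) and so moves the number in the weaker direction. Going by these compounds alone, this is the first sign that the aryl group at this place affects the result, since the earlier compounds both carry 4-bromophenyl. No available evidence explains the step.

The step covers the exchange as a whole, so the compounds shown do not tell whether the change of substituent or the change of its ring position accounts for it. On these data alone, a 4-methoxyphenyl or 3-bromophenyl group on the same chain would separate the two, and how 3-methoxyphenyl behaves on the chain of compound 2 also remains open.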